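A few compounds are considered here, and "the series" means these few. Any claim that something is new, unique, unknown or untested is made for them only; others in the source may bear on it.

Compound 1 `CN1CCC[C@@H]1Cn1nc(CC2CCCCC2)c2ccccc2c1=O`: in an assay for binding affinity to Alpha-1B adrenergic receptor (Homo sapiens) (a higher number here means a weaker inhibitor, a lower number a stronger inhibitor), compound 1 gives > 1990 nM, which is a limit of the assay and not a measured number.
Compound 2 `CN(CCCCc1ccc(OCCCN2CCCCCC2)cc1)CCn1nc(Cc2ccc(Cl)cc2)c2ccccc2c1=O`: in this assay compound 2 gives > 1990 nM, likewise a limit rather than a number.

Compound 1 therefore stands at the upper edge of what this assay can report; both values shown sit at that same limit (the limit of > 1990 nM in this assay, at which 2 of the 2 values shown sit). For the measured compounds named here, no two measured compounds differ in just one place, so there is no measured step to anchor a prediction. The unmeasured compound 3 `COc1ccc(Cc2nn(C[C@H]3CCCN3C)c(=O)c3ccccc23)cc1` differs from compound 1 in one place: 4-methoxyphenyl in place of cyclohexyl on a saturated chain carbon bound to an aromatic carbon. Going by the values given here, with compound 1 resting at a limit and compound 2 also at a limit, the data give no measured step of any size and no direction. Compound 3 is expected to stay close to where compound 1 stands, so the expected step that the limit leaves unreadable from compound 1 to compound 3 is taken to be no larger than the usual scatter, and the assay may well again report only a limit. For compound 3 the estimate in this assay is 4000 nM, expected to fall between 1500 nM and 15000 nM.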

Compound 3, inhibition constant: 158 nM
For compound 3 the middle estimate is 25-fold (1.40 log units) above the measured one; measured number outside the range, below it.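

This place, on a saturated chain carbon bound to an aromatic carbon, clearly matters in this assay: 4-methoxyphenyl in place of cyclohexyl gives an at least 12-fold lower number from compound 1 to compound 3 (1.10 log units; beyond the scatter), the only measured step shown here and one beyond the usual scatter. With this single change, compound 3 gives 158 nM, the only actual number among the compounds shown, so a change at this one place is enough to bring the series within what the assay can read. Going by these compounds, the true size of the step stays unknown because compound 1 rests at a limit rather than a number: the limit of > 1990 nM in this assay, at which 2 of the 3 values shown sit.

The change replaces a non-aromatic ring with an aromatic one and adds a methoxy group at the same time, so the compounds shown cannot say which of the two accounts for the step. A plain phenyl in this place would separate the ring from the methoxy group, and a 4-ethoxyphenyl or 3-methoxyphenyl would show how much the exact form and place of that group count.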